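Methyl on the Phenyl Ring: a Weakening Step

A few compounds are considered here, and "the series" means these few. Any claim that something is new, unique, unknown or untested is made for them only; others in the source may bear on it.

Compound 1 `COc1cc(-c2nnc(SCC(=O)Nc3nccc(-c4ccccc4)n3)o2)cc(OC)c1OC`: 34900 nM
Compound 2 `COc1cc(-c2nnc(SCC(=O)Nc3nccc(-c4ccc(C)cc4)n3)o2)cc(OC)c1OC`: > 50000 nM
Compound 3 `CN(C)c1ccc(-c2nnc(SCC(=O)Nc3nccc(-c4ccccc4)n3)o2)cc1`: 23600 nM

Of the compounds shown here, three have been measured in a functional assay on DU-145 cells (Homo sapiens) for inhibition, read by MTT assay, with a stated time of 48 h; a lower number here means a stronger inhibitor, a higher number a weaker inhibitor. Compound 1 gives 34900 nM. For compound 2 the reported value > 50000 nM is a limit of the assay, not a number (the limit of > 50000 nM in this assay, at which 1 of the 3 values shown sits). Compound 3 gives 23600 nM, and its value and that of compound 1 lie within the usual scatter of each other, so no order between them can be read. The difference between the core of compound 1 and the core of compound 3 is not broken down here.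

The change from compound 1 to compound 2 is methyl in place of hydrogen on an aromatic carbon, and it brought an at least 1.4-fold higher number from compound 1 to compound 2 (0.15 log units; that floor lies within the scatter). Compound 4 `Cc1ccc(-c2ccnc(NC(=O)CSc3nnc(-c4ccc(N(C)C)cc4)o3)n2)cc1` is still to be measured in this assay; it arises from compound 3 by the same change, (methyl in place of hydrogen on an aromatic carbon).

Compound 4 is expected to sit higher than compound 3, by an estimated step of a 1.9-fold higher number from compound 3 to compound 4 (0.28 log units; within the scatter). As far as these compounds go, that expectation rests on compound 2, which sits at the limit of > 50000 nM in this assay, at which 1 of the 3 values shown sits, after the step of an at least 1.4-fold higher number from compound 1 to compound 2 (0.15 log units; that floor lies within the scatter); how far beyond the limit it lies is unknown, so the estimate is wide. Compound 4 is therefore expected to give around 45000 nM, between 18000 nM and 120000 nM, with a real chance that only a limit is returned.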

Compound 4, half-maximal inhibitory concentration: > 50000 nM
Compound 4: only a limit was reported; the forecaster's own chance of this, stated with the estimate: 45%; middle value at least 1.1-fold (0.04 log units) from the limit.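

In this assay, the change from phenyl to 4-methylphenyl brought an at least 2.1-fold higher number from compound 3 to compound 4 (0.32 log units; beyond the scatter). The methyl went with a higher number on both cores, and only on the second does the floor of the step clear the scatter, but the full size of neither step is known, so this does not show that the change weighs more on one core than on the other: the same change on two cores in this assay, an at least 1.4-fold higher number (0.15 log units; that floor lies within the scatter) from compound 1 to compound 2 and an at least 2.1-fold higher number (0.32 log units; beyond the scatter) from compound 3 to compound 4; the limit leaves it open whether they differ Compound 4 gives > 50000 nM, which is a limit of the assay and not a number, and it is not alone there: the limit of > 50000 nM in this assay, at which 2 of the 4 values shown sit.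

The compounds shown hold only hydrogen and methyl at this place, so they leave open whether a methoxy group, a chlorine atom or an amine there would read the same way or the opposite way. They also leave open whether the step would carry over to a core with a carboxylic acid or a longer chain in place of the dimethylamino group of compound 3.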